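Compound 2 and its mirror image, compound 3

This account rests on a few compounds, and the source may have more. Where it says the series, first, only, none or still open, it means among the compounds named here.

Measured in a physicochemical assay for solubility, in phosphate buffer, measured as kinetic solubility, with a stated time of 1 h, at pH 7.4; on this read-out higher numbers stand for higher solubility and lower numbers for lower solubility:
Compound 1 `CS(=O)(=O)Cc1cc(C2=CCOCC2)nc(-c2cccc(O)c2)n1`: 27 ug/mL
Compound 2 `CS(=O)(=O)Cc1cc([C@]23CCOC[C@H]2C3)nc(-c2cccc(O)c2)n1`: 75 ug/mL

Of these two compounds, compound 2 has the higher number. For the measured compounds named here, the only measured step is a 2.8-fold higher number from compound 1 to compound 2 (0.44 log units; beyond the scatter). That step swaps one group for another, so it bears only loosely on compound 3 `CS(=O)(=O)Cc1cc([C@@]23CCOC[C@@H]2C3)nc(-c2cccc(O)c2)n1`, the next compound. The change here is the two compounds have the same atoms and bonds and differ only in configuration as drawn: 2 of 2 stereo elements differ (all stereocentres are inverted: mirror images); a stereocentre at a saturated ring carbon is drawn R in compound 2 and S in compound 3; a stereocentre at a saturated ring carbon is drawn S in compound 2 and R in compound 3. Going by the values given here, no pair of mirror images has been measured yet, so this rests on the structures alone. The estimated step, expected to stay within the scatter, is no change at the digits printed from compound 2 to compound 3 (within the scatter). The expected value for compound 3 is 75 ug/mL, with an estimated range of 42 ug/mL to 130 ug/mL.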

Compound 3, solubility: 145 ug/mL
Beside the measured number, compound 3's estimate is 1.9-fold (0.29 log units) below it, and the stated range ends below it.
By their numbers in this assay, from the lowest: compound 1; then compounds 2 and 3 (each within the scatter of the next).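

In this assay, the first mirror-image pair gives a 1.9-fold higher number from compound 2 to compound 3 (0.29 log units; within the scatter), so inverting both stereocentres moves the number no further than the usual scatter, in a comparison where nothing else varies: the fact that compounds 2 and 3 differ only in the configuration as drawn. Both mirror forms of the group of 7 heavy atoms also stand clear of the group of 6 heavy atoms, as the earlier step did and as a 5.4-fold higher number from compound 1 to compound 3 (0.73 log units; beyond the scatter) now confirms.

Still open, as far as these compounds go, is whether an amine in place of the ring oxygen, or a longer chain on that aromatic carbon, would shift this number.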